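Dihydro core series: fluoro swapped for propylcarbamoyl

This account rests on a few compounds, and the source may have more. Where it says the series, first, only, none or still open, it means among the compounds named here.

Measured so far:
- compound 1 `CCC1C(=O)N(C)c2cnc(Nc3ccc(S(=O)(=O)NCCO)cc3)nc2N1c1ccn(C)n1` gives "not active" (no number reported) with no number reported
- compound 2 `CC[C@@H]1C(=O)N(C)c2cnc(-n3ccc4cc(F)ccc43)nc2N1C1CCCC1` gives 16000 nM as the one number

For the measured compounds named here, in a functional assay on Huh-7 cells (Homo sapiens) for antiproliferative activity, read by CCK-8 assay, with a stated time of 72 h (a higher number here means a weaker inhibitor of growth, a lower number a stronger inhibitor of growth), compound 2 gives 16000 nM as the only number available, and the single further entry, compound 1, comes without a number. Going by the values given here, compound 2 therefore has no numerical neighbour, and no step between measured compounds exists to calibrate the next change.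

Compound 3 `CCCNC(=O)c1ccc2c(ccn2-c2ncc3c(n2)N(C2CCCC2)[C@H](CC)C(=O)N3C)c1` is still to be measured. It keeps the shared core of compound 2 and carries propylcarbamoyl in place of fluoro on an aromatic carbon and nothing else changes.

Among the compounds with values here, with no measured step to lean on, the expectation rests on the starting point alone. Compound 2 at 16000 nM already sits at a weak level of growth inhibition, so there is more room for a gain than for a loss. What is expected is a 2.7-fold lower number from compound 2 to compound 3 (0.43 log units; beyond the scatter) as a modest move toward stronger inhibition, held with low confidence. A result without a number also remains possible, as seen for compound 1 at "not active" (no number reported) in the same read-out.

In this assay the estimate for compound 3 is 6000 nM with an expected range from 1000 nM to 30000 nM as the working figure.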

Compound 3, concentration for 50% growth inhibition: 689 nM
Beside the measured number, compound 3's estimate is 8.7-fold (0.94 log units) above it, outside the stated range (below it).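

In this assay, propylcarbamoyl in place of fluoro on this aromatic carbon gives a 23-fold lower number from compound 2 to compound 3 (1.37 log units; beyond the scatter), a large step and the first measured one in the series, so this position is clearly sensitive to the group it carries. The step also shows that the position accepts a much larger group than fluoro, with growth inhibition improving rather than being lost, but the entering group brings a carbonyl, an amide hydrogen and a propyl chain together, and one step cannot separate their contributions. No measurement accompanying the result bears on the reason for this gain.

Still open, going by these compounds, is which part of propylcarbamoyl carries the gain, and how a primary carboxamide, a tertiary amide without the amide hydrogen, a longer chain on the amide nitrogen or a carboxylic acid on the same carbon would read out. On these data alone, compound 1 differs from the other two compounds in more than one place, so its entry says nothing about this position, and whether the gain holds with other groups elsewhere on the shared core also remains open.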